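Bromo for nitro on the aryl of compound 2

The source may hold more compounds than are shown below. What is called first, only, known or untested is meant among the compounds shown, and "the series" means these compounds.

Compound 2 `O=Cc1c(-c2ccc([N+](=O)[O-])cc2)nc2sc(Cc3ccccc3)nn12` is one of three congeners measured in a functional assay on cells (Leukemia cell, Homo sapiens) for inhibition; a higher number here means a weaker inhibitor of growth, a lower number a stronger inhibitor of growth. Compound 2 gives 26300 nM. Compound 1 `N#CSc1c(-c2ccccc2)nc2sc(Cc3ccccc3)nn12` gives 57500 nM in this assay, and compound 3 `O=Cc1c(-c2ccc(F)cc2)nc2sc(CCC3CCCCC3)nn12` gives 70800 nM. Compound 2 therefore stands lowest of the three numbers; its gap to compound 1 and its larger gap to compound 3 both lie beyond the scatter. Going by the values given here, compounds 1 and 3 each differ from compound 2 in more than one place, so no single step between measured compounds is at hand.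

Compound 4 `O=Cc1c(-c2ccc(Br)cc2)nc2sc(Cc3ccccc3)nn12` differs from compound 2 by bromo in place of nitro on an aromatic carbon, the bromo sitting on an aromatic carbon of the six-membered aromatic ring of carbon only, para to a large group. Among the compounds with values here, no measured pair isolates this exchange, so the size of the step is uncertain; a modest move toward a higher number, or none beyond the scatter, is expected. The estimate for compound 4 in this assay is 40000 nM, within 15000 nM to 110000 nM. This estimate means a step of a 1.5-fold higher number from compound 2 to compound 4 (0.18 log units; within the scatter), expected rather than measured.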

Compound 4, concentration for total growth inhibition: 13500 nM
Compound 4: middle estimate off by 3.0-fold (0.47 log units), on the high side; the measured number lies below the stated range.
By their numbers in this assay, from the lowest: compounds 4 and 2 (each within the scatter of the next); then compounds 1 and 3 (each within the scatter of the next).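

In the only comparison among these compounds that differs in one place, this assay gives a 1.9-fold lower number from compound 2 to compound 4 (0.29 log units; within the scatter) for bromo in place of nitro on the aromatic carbon. This position of the six-membered aromatic ring therefore accepts either group without a change beyond the scatter, even though nitro brings hydrogen-bond acceptors and a double bond outside aromatic rings, and bromo brings neither. No measurement here explains why the two groups read alike.

From the compounds shown here alone, whether an amine, a carboxylic acid or a methoxy group at this place would keep the number within the scatter of compounds 2 and 4 remains open. Also open, going by these compounds, is whether bromo and nitro would read alike on the core of compound 3, with its longer chain bearing a cyclohexyl ring.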